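A few compounds are considered here, and "the series" means these few. Any claim that something is new, unique, unknown or untested is made for them only; others in the source may bear on it.

The shared core of compound 1 `CCCCCC1(OC)CCN(c2ccc(C(=O)NS(=O)(=O)c3ccc(N[C@H](CCN(C)C)CSc4ccccc4)c([N+](=O)[O-])c3)cc2)CC1` is kept throughout the series, and variation sits only on the saturated ring. In a functional assay (FL5.12 cells, Mus musculus) with Apoptosis regulator Bcl-2 (Homo sapiens) as the target (on this read-out lower numbers stand for an effect already at smaller amounts and higher numbers for an effect only at larger amounts of compound), compound 1 gives 3000 nM. Compound 2 `COC1(Cc2ccccc2C)CCN(c2ccc(C(=O)NS(=O)(=O)c3ccc(N[C@H](CCN(C)C)CSc4ccccc4)c([N+](=O)[O-])c3)cc2)CC1` gives 200 nM, and compound 3 `COc1ccccc1CC1(OC)CCN(c2ccc(C(=O)NS(=O)(=O)c3ccc(N[C@H](CCN(C)C)CSc4ccccc4)c([N+](=O)[O-])c3)cc2)CC1` gives 250 nM. Compound 3 stands second highest of the three numbers; its nearest neighbour is compound 2, within the scatter, while compound 1 lies far higher. For the measured compounds named here, two steps bear on the aryl group: a 15-fold lower number from compound 1 to compound 2 (1.18 log units; beyond the scatter) and a 12-fold lower number from compound 1 to compound 3 (1.08 log units; beyond the scatter), so exchanging butyl for a 2-substituted phenyl counted for a large gain. Between the two aryl groups, a 1.3-fold higher number from compound 2 to compound 3 (0.10 log units; within the scatter), the substituent itself made no difference beyond the scatter. Compound 4 `COC1(Cc2ccccc2-c2ccccc2)CCN(c2ccc(C(=O)NS(=O)(=O)c3ccc(N[C@H](CCN(C)C)CSc4ccccc4)c([N+](=O)[O-])c3)cc2)CC1` carries phenyl in place of methoxy on an aromatic carbon. Going by the values given here, no measured pair varies this position with a group of that size, so the expectation rests on the two small-substituent analogues alone. Compound 4 is therefore expected to give a step of a 1.2-fold higher number from compound 3 to compound 4 (0.08 log units; within the scatter). The estimate for compound 4 is 300 nM, within 100 nM to 1000 nM.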

Compound 4, half-maximal effective concentration: 20 nM
Beside the measured number, compound 4's estimate is 15-fold (1.18 log units) above it, outside the stated range (below it).
By their numbers in this assay, from the lowest: compound 4; then compounds 2 and 3 (each within the scatter of the next); then compound 1.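

In this assay this position proves not to be indifferent to the group on the aromatic carbon: a 13-fold lower number from compound 3 to compound 4 (1.10 log units; beyond the scatter) and a 10-fold lower number from compound 2 to compound 4 (1.00 log units; beyond the scatter), both beyond the scatter, although the methyl and methoxy analogues stayed within the scatter of each other. Among the compounds shown, the further gain comes only with phenyl, the one substituent that brings a six-membered aromatic ring of carbon only, and the full exchange of butyl for 2-phenylphenyl reaches a 150-fold lower number from compound 1 to compound 4 (2.18 log units; beyond the scatter). No evidence on the cause of this gain is available.

The compounds shown leave open whether any ring at this place carries the gain or only an aromatic one, which a cyclohexyl or pyridyl group in place of the phenyl would test. Also open, from the compounds shown here alone, is how a carboxylic acid or a dimethylamino group on the entering phenyl would shift the number.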